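The source may hold more compounds than are shown below. What is called first, only, known or untested is meant among the compounds shown, and "the series" means these compounds.

Three compounds of this series carry a read-out in a functional assay on CHO cells for agonist activity at adenosine receptor A1 (Homo sapiens), read by fluorescence and ERK phosphorylation, with stated times of 30 min and 1.5 h, tested at 3 uM; on this read-out higher numbers stand for a stronger effect at the one concentration tested and lower numbers for a weaker effect. Compound 1 `Nc1scc(-c2cccc([N+](=O)[O-])c2)c1C(=O)c1ccc(Cl)cc1` gives 53% in this assay. Compound 3 `COc1cccc(-c2csc(N)c2C(=O)c2ccc(Cl)cc2)c1` gives 58% in this assay; it is reached from compound 1 through (methoxy in place of nitro on an aromatic carbon), a step of a number 5 percentage points higher from compound 1 to compound 3 (within the scatter). Compound 2 `Nc1scc(-c2ccc([N+](=O)[O-])cc2)c1C(=O)c1ccc(Cl)cc1` gives 47% in this assay; the difference between the cores of compound 1 and compound 2 is not broken down here. Compound 4 `COc1ccc(-c2csc(N)c2C(=O)c2ccc(Cl)cc2)cc1` is not yet measured; it is reached from compound 2 through (methoxy in place of nitro on an aromatic carbon). This is the same kind of change as from compound 1 to compound 3, but the place differs: meta to a large group there, para to a large group here. For compound 4 a step of about a number 5 percentage points higher from compound 2 to compound 4 (within the scatter) is expected because the same kind of change gave a number 5 percentage points higher from compound 1 to compound 3 (within the scatter). Compound 4 is estimated at 52% in this assay, with a range from 40% to 64%.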

Compound 4, a percentage reported as activity, at one concentration (the size of the read-out at that concentration, not a potency): 51%
Beside the measured number, compound 4's estimate is 1 percentage points above it; measured number inside the range.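

In this assay, methoxy in place of nitro on an aromatic carbon, para to a large group, gives a number 4 percentage points higher from compound 2 to compound 4 (within the scatter), and the change carries over between the two cores with no difference that can be told apart: the same change on two cores in this assay, a number 5 percentage points higher (within the scatter) from compound 1 to compound 3 and a number 4 percentage points higher (within the scatter) from compound 2 to compound 4, 1 percentage points apart, within the scatter of two such steps. For the compounds shown here, both steps lie within the scatter, so the pair shows only that this swap leaves the read-out about where it stood on either core. It shows no gain of methoxy over nitro, and a read-out at one concentration says nothing about potency.

The compounds shown hold only nitro and methoxy on this ring. On these data alone, whether an amine, a carboxylic acid or a longer chain in the same place would move the read-out beyond the scatter remains open.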